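The source may report more compounds than this note shows. Statements on the series, on what has been measured and on what is new or still open speak of the compounds shown alone.

Among the compounds with values here, compound 3 `CC1=NC(C)=C(C(=O)O)C(c2cccc(Cl)c2)/C1=C(\O)OC/C=C/c1ccc(Cl)cc1` stands second highest of the three numbers so far in a functional assay on thoracic aorta for inhibition of Voltage-gated L-type calcium channel (Rattus norvegicus) (a higher number here means a weaker inhibitor, a lower number a stronger inhibitor), where compound 3 gives 5.8 nM. Its nearest neighbour is compound 2 `CC1=NC(C)=C(C(=O)O)C(c2cccc(Cl)c2)/C1=C(\O)OC/C=C/C1CCCCC1`, which in this assay gives 3.7 nM; the step of a 1.6-fold higher number from compound 2 to compound 3 (0.20 log units; within the scatter) lies within the scatter. The furthest is compound 1 `CC1=NC(C)=C(C(=O)O)C(c2cccc(Cl)c2)/C1=C(\O)OC/C=C/c1ccccc1`, which in this assay gives 20 nM; the step of a 3.4-fold lower number from compound 1 to compound 3 (0.54 log units; beyond the scatter) lies beyond the scatter.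

Compound 4 `CC1=NC(C)=C(C(=O)O)C(c2cccc(Cl)c2)/C1=C(\O)OC/C=C/c1ccc(C)cc1` differs from compound 3 in one place: methyl in place of chloro on an aromatic carbon. Within the data shown here, no measured step exchanges chloro for methyl directly. The step that bears most closely is a 3.4-fold lower number from compound 1 to compound 3 (0.54 log units; beyond the scatter), which shows that filling this aromatic carbon with chloro rather than hydrogen gives a modestly lower number. The step of a 5.4-fold lower number from compound 1 to compound 2 (0.73 log units; beyond the scatter) shows a further modest lowering when the whole phenyl is exchanged for cyclohexyl. Methyl, like chloro, fills the same aromatic carbon, so compound 4 is expected to stay near compounds 2 and 3 rather than return to the number of compound 1.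

The step of a 1.4-fold higher number from compound 3 to compound 4 (0.14 log units; within the scatter) is expected to stay within the scatter. Compound 4 is estimated to give 8 nM in this assay, with a range from 3 nM to 25 nM.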

Compound 4, half-maximal inhibitory concentration: 6.8 nM
For compound 4 the middle estimate is 1.2-fold (0.07 log units) above the measured one, within the range that was stated.
By their numbers in this assay, from the lowest: compounds 2, 3 and 4 (each within the scatter of the next); then compound 1.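

In this assay, a 2.9-fold lower number from compound 1 to compound 4 (0.47 log units; beyond the scatter), so methyl joins chloro as a second group on this aromatic carbon, para to a large group, that gives a modestly lower number than hydrogen. The exchange of chloro for methyl, a 1.2-fold higher number from compound 3 to compound 4 (0.07 log units; within the scatter), does not separate the two groups, and a 1.8-fold higher number from compound 2 to compound 4 (0.26 log units; within the scatter) likewise does not separate 4-methylphenyl from cyclohexyl, which leaves compound 1 as the only one of the four set apart from the others by steps beyond the scatter. No measurement at hand accounts for the chlorine and carbon substituents giving values that cannot be told apart.

The compounds shown leave open whether the lowering seen with chloro and methyl extends to an amine, a carboxylic acid or a longer chain such as butyl on this same aromatic carbon. From the compounds shown here alone, it also remains open whether chloro or methyl on a different carbon of this ring would give a number near those of compound 3 and compound 4 or nearer that of compound 1.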